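Pyridyl in Place of Cyanophenyl on a Shared Core

This account rests on a few compounds, and the source may have more. Where it says the series, first, only, none or still open, it means among the compounds named here.

Measured compounds in an in vitro assay on HEK385-7 cells for displacement of a labelled ligand from prostaglandin D2 receptor 2 (Homo sapiens); on this read-out lower numbers stand for stronger inhibition and higher numbers for weaker inhibition:
compound 1, `O=C(O)Cc1sc(NC(=O)c2ccccc2)nc1-c1ccc(Cl)cc1`: 520 nM
compound 2, `O=C(O)Cc1sc(C(Cc2ccccc2)c2ccccc2)nc1-c1ccc(Cl)cc1`: 56 nM
compound 3, `N#Cc1ccc(-c2nc(C(c3ccc(F)cc3)c3ccc(F)cc3)sc2CC(=O)O)cc1`: 150 nM

Among these three numbers compound 3 stands second highest. Its nearest neighbour is compound 2, whose number is lower by a margin beyond the usual scatter, while compound 1 lies furthest away with a higher number, also beyond the scatter. Compound 4, `O=C(O)Cc1sc(C(c2ccc(F)cc2)c2ccc(F)cc2)nc1-c1ccncc1`, differs from compound 3 by pyridin-4-yl in place of 4-cyanophenyl on an aromatic carbon. Among the compounds with values here, no pair of measured compounds differs in only one place, so the size of this step has no precedent here. A modest move toward weaker inhibition is expected, estimated as a 2.0-fold higher number from compound 3 to compound 4 (0.30 log units; within the scatter). In this assay compound 4 is therefore expected to give about 300 nM, with a range from 80 nM to 1200 nM.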

Compound 4, half-maximal inhibitory concentration: 5.3 nM
Compound 4: the middle estimate sits 57-fold (1.75 log units) above what was measured; the measured number lies below the stated range.
By their numbers in this assay, from the lowest: compound 4; then compound 2; then compound 3; then compound 1.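

In this assay the step of a 28-fold lower number from compound 3 to compound 4 (1.45 log units; beyond the scatter) shows that this aromatic carbon, next to the ring nitrogen, responds strongly to the group it carries. The earlier compounds shown here differ in more than one place and could not show this. Both groups carry one hydrogen-bond acceptor, so that count does not separate them, and nothing measured here accounts for the step.

The compounds shown leave open how a plain phenyl, a pyridin-3-yl or a pyrimidin-5-yl group would compare at this position. They also leave open whether a 4-cyanophenyl to pyridin-4-yl swap would give a similar step with two unsubstituted phenyl groups on the large group.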